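From a Methylphenyl to a Fluorophenyl on the Ring Nitrogen

The source may report more compounds than this note shows. Statements on the series, on what has been measured and on what is new or still open speak of the compounds shown alone.

Compound 1, `Cc1ccccc1-n1cc(-c2cccc(NS(=O)(=O)c3c[nH]c(=O)[nH]c3=O)c2)nn1`: 9570 nM
Compound 2, `Cc1cccc(-n2cc(-c3cccc(NS(=O)(=O)c4c[nH]c(=O)[nH]c4=O)c3)nn2)c1`: 7050 nM
Compound 3, `Cc1ccc(-n2cc(-c3cccc(NS(=O)(=O)c4c[nH]c(=O)[nH]c4=O)c3)nn2)cc1`: > 20000 nM

All three share one core and differ only in the group on an aromatic nitrogen, measured in a functional assay on HepG2 cells (Homo sapiens) for antiproliferative activity, read by MTT assay, with a stated time of 24 h; on this read-out lower numbers stand for stronger inhibition and higher numbers for weaker inhibition. Compound 3 stands at the limit of > 20000 nM in this assay, at which 1 of the 3 values shown sits, which is a limit of the assay and not a number. The steps of an at least 2.0-fold higher number from compound 1 to compound 3 (0.32 log units; beyond the scatter) and an at least 2.8-fold higher number from compound 2 to compound 3 (0.45 log units; beyond the scatter) show weaker inhibition with the 4-methylphenyl, while a 1.4-fold lower number from compound 1 to compound 2 (0.13 log units; within the scatter) lies within the scatter. Compound 4, `O=c1[nH]cc(S(=O)(=O)Nc2cccc(-c3cn(-c4ccccc4F)nn3)c2)c(=O)[nH]1`, brings (2-fluorophenyl in place of 4-methylphenyl on an aromatic nitrogen). Compound 4 carries its substituent in the 2-position of the phenyl, as compound 1 does. Compound 4 is therefore expected to return toward the value of compound 1, estimated at 10000 nM with a range of 4000 nM to 25000 nM. The expected step is an at least 2.0-fold lower number from compound 3 to compound 4 (0.30 log units; that floor lies within the scatter).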

Compound 4, half-maximal inhibitory concentration: 13900 nM
Compound 4: the middle estimate sits 1.4-fold (0.14 log units) below what was measured, within the range that was stated.
By their numbers in this assay, from the lowest: compounds 2, 1 and 4 (each within the scatter of the next). At a limit, above all of these: compound 3.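

In this assay, fluoro stands in for methyl on the phenyl without a change beyond the scatter: a 1.5-fold higher number from compound 1 to compound 4 (0.16 log units; within the scatter). The 2-fluorophenyl also stays within the scatter of the 3-methylphenyl: a 2.0-fold higher number from compound 2 to compound 4 (0.29 log units; within the scatter). Against the 4-methylphenyl the step is only a floor, an at least 1.4-fold lower number from compound 3 to compound 4 (0.15 log units; that floor lies within the scatter), and compound 3 is held by a limit of the assay and not a number: the limit of > 20000 nM in this assay, at which 1 of the 4 values shown sits.

The compounds shown leave open whether a 4-fluorophenyl would read like the 2-fluorophenyl or like the 4-methylphenyl. They also leave open how a phenyl carrying an amine or a carboxylic acid would read.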